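Hydroxy for methoxy on the chlorophenyl arm

The source may report more compounds than this note shows. Statements on the series, on what has been measured and on what is new or still open speak of the compounds shown alone.

Going by the values given here, compound 2 `COc1cc(-c2nn(-c3cccc(NC(=O)Nc4cc(C(F)(F)F)cc(C(F)(F)F)c4)c3)cc2-c2ccncc2)ccc1Cl` is the one compound of the pair with a number in a functional assay on MCF7 cells (Homo sapiens) for inhibition, read by sulforhodamine B assay, with a stated time of 48 h (a higher number here means a weaker inhibitor of growth, a lower number a stronger inhibitor of growth), where compound 2 gives 10900 nM. Compound 1 `O=C(Nc1cccc(-n2cc(-c3ccncc3)c(-c3ccc(Cl)c(O)c3)n2)c1)Nc1cccc(C(F)(F)F)c1` gives only a limit in this assay, > 32500 nM. the limit of > 32500 nM in this assay, at which 1 of the 2 values shown sits, marks where that limit sits. Compound 3 `O=C(Nc1cccc(-n2cc(-c3ccncc3)c(-c3ccc(Cl)c(O)c3)n2)c1)Nc1cc(C(F)(F)F)cc(C(F)(F)F)c1` follows from compound 2 by hydrogen in place of methyl on an oxygen on an aromatic ring, which is hydrogen in place of methyl on an oxygen on an aromatic ring; read one bond further out, methoxy becomes hydroxy and 4-chloro-3-methoxyphenyl becomes 4-chloro-3-hydroxyphenyl. Compound 3 shares its hydroxy group with compound 1 and its two trifluoromethyl groups with compound 2. Among the compounds with values here, no measured step between two compounds differing in one place is available, so the size of the move is open. The step from compound 2 to compound 3 is expected to be a 1.8-fold higher number from compound 2 to compound 3 (0.26 log units; within the scatter), a loss that may reach beyond the scatter. Compound 3 is therefore estimated at 20000 nM, within 8000 nM to 45000 nM, with a real chance that only a limit is returned.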

Compound 3, concentration for total growth inhibition: 5790 nM
The estimate for compound 3 lay 3.5-fold (0.54 log units) above the measured number, outside the stated range (below it).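

In this assay, hydroxy in place of methoxy on the aromatic ring gives a 1.9-fold lower number from compound 2 to compound 3 (0.27 log units; within the scatter), so this position accepts the free hydroxy group with no change beyond the scatter. Going by these compounds alone, with hydroxy held constant, the added trifluoromethyl group gives an at least 5.6-fold lower number from compound 1 to compound 3 (0.74 log units; beyond the scatter), which places the one step beyond the scatter at the trifluoromethyl change and not at the oxygen. Compound 1 gives only a limit, so this second step has a minimum size and no exact one: the limit of > 32500 nM in this assay, at which 1 of the 3 values shown sits.

Going by these compounds, whether the oxygen tolerates a longer chain, such as ethoxy or benzyloxy, remains open, as does the effect of an amine or a carboxylic acid in place of the hydroxy group. Also open, on these data alone, is the size of the trifluoromethyl step when methoxy occupies this position.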